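The compounds below may be only part of what the source reports. "The series", "measured", "known", "first", "only" and "open" are said of these compounds alone.

In a functional assay on the whole organism for inhibition, with Lemna aequinoctialis as the target, with a stated time of 7 days, tested at 500 ug/mL (on this read-out lower numbers stand for less inhibition of growth and higher numbers for more inhibition of growth at the one concentration tested), compound 1 `O=C1Nc2ccc(F)cc2/C1=N/NC(=S)Nc1ccc(F)cc1` gives 35% while compound 2 `O=C1Nc2ccc(F)cc2/C1=N/NC(=S)Nc1ccc(F)cc1F` gives 30% and compound 3 `O=C1Nc2ccc(F)cc2/C1=N/NC(=S)Nc1c(F)cccc1F` gives 30% so that compound 3 stands level with compound 2 and within the scatter of compound 1. Compound 4 `O=C1Nc2ccc(F)cc2/C1=N/NC(=S)Nc1cc(F)cc(F)c1` differs from compound 3 in one place, with 3,5-difluorophenyl in place of 2,6-difluorophenyl on an amide-type nitrogen and no other change. Three measured steps bear on this: no change at the digits printed from compound 2 to compound 3 (within the scatter) and a number 5 percentage points lower from compound 1 to compound 3 (within the scatter) and also a number 5 percentage points lower from compound 1 to compound 2 (within the scatter) among these fluorinated phenyl groups. None leaves the scatter, so no step beyond it is expected. The expected step is no change at the digits printed from compound 3 to compound 4 (within the scatter) with no direction favoured. For compound 4 the estimated value is 30% with an expected range from 18% to 42% around it.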

Compound 4, percent growth inhibition at one concentration: 15%
Compound 4: middle estimate off by 15 percentage points, on the high side, and the stated range ends above it.
By their numbers in this assay, from the lowest: compound 4; then compounds 2, 3 and 1 (each within the scatter of the next).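

In this assay, going by these compounds alone, 3,5-difluorophenyl on the amide-type nitrogen gives the first steps at this place that leave the scatter: a number 15 percentage points lower from compound 3 to compound 4 (beyond the scatter) and a number 15 percentage points lower from compound 2 to compound 4 (beyond the scatter) and a number 20 percentage points lower from compound 1 to compound 4 (beyond the scatter). The earlier fluorinated phenyl groups stayed within the scatter of one another, so the same atoms joined differently can change this read-out. Nothing measured here accounts for the drop.

Going by these compounds, whether a 3,5-dichlorophenyl or 3,5-dimethoxyphenyl group would give a similar number remains open, as does the effect of a plain phenyl group.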